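Cyclohexyl in place of methyl, measured against a limit

The source may report more compounds than this note shows. Statements on the series, on what has been measured and on what is new or still open speak of the compounds shown alone.

Measured so far in a functional assay on MCF7 cells (Homo sapiens) for inhibition; a higher number here means a weaker inhibitor of growth, a lower number a stronger inhibitor of growth:
- compound 1 `COC(=O)c1ccsc1NC(=O)[C@@H]1CCCN1` gives > 250 ug/mL
- compound 2 `CCOC(=O)c1ccsc1NC(=O)[C@@H]1CCCN1` gives > 250 ug/mL
- compound 3 `O=C(Oc1ccccc1)c1ccsc1NC(=O)[C@@H]1CCCN1` gives > 250 ug/mL

Compound 1 stands at a limit and not at a number. The same holds for compound 2 and compound 3, which leaves the limit of > 250 ug/mL in this assay, at which 3 of the 3 values shown sit, as all that is known so far.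

Compound 4 `O=C(OC1CCCCC1)c1ccsc1NC(=O)[C@@H]1CCCN1` has not yet been measured. Its difference from compound 1 is cyclohexyl in place of methyl on an oxygen next to a carbonyl group in all, with cyclohexyl in place of methyl on an oxygen next to a carbonyl group.

For the measured compounds named here, three measured steps bear on this change. The change to ethyl is a step that the two limits leave unreadable from compound 1 to compound 2 and the change to phenyl is a step that the two limits leave unreadable from compound 1 to compound 3 while the exchange of ethyl for phenyl is a step that the two limits leave unreadable from compound 2 to compound 3 in the same read-out. None of them offers a size to carry over, so no direction follows and no change beyond the scatter is expected. The expected result is a number no higher from compound 1 to compound 4 (the limit leaves the size open) and it rests on nothing firmer than those limits. For compound 4 the estimated concentration is 250 ug/mL with an expected range from 120 ug/mL to 500 ug/mL in this assay and a further limit is the likeliest report.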

Compound 4, concentration for 50% growth inhibition: 162 ug/mL
Compound 4: the middle estimate sits 1.5-fold (0.19 log units) above what was measured, and the stated range covers the measured number.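

On an oxygen next to a carbonyl group, cyclohexyl is the only one of the four groups shown that gives a number rather than a limit in this assay: the limit of > 250 ug/mL in this assay, at which 3 of the 4 values shown sit.

Read against those limits, the change gives an at least 1.5-fold lower number from compound 1 to compound 4 (0.18 log units; that floor lies within the scatter), an at least 1.5-fold lower number from compound 2 to compound 4 (0.18 log units; that floor lies within the scatter) and an at least 1.5-fold lower number from compound 3 to compound 4 (0.18 log units; that floor lies within the scatter). From the compounds shown here alone, each of these is only a floor, so the full size of the change stays open, and the steps among compound 1, compound 2 and compound 3 cannot be read.

The compounds shown leave open whether a measurable number in this assay needs the cyclohexyl ring itself or would also come with a longer chain such as hexyl on the same oxygen. They also leave open how an amine or a carboxylic acid on the cyclohexyl ring would read there.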